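A few compounds are considered here, and "the series" means these few. Any claim that something is new, unique, unknown or untested is made for them only; others in the source may bear on it.

For the measured compounds named here, in a functional assay on T98G cells (Homo sapiens) for inhibition, read by colorimetric assay and MTT assay, with a stated time of 72 h (on this read-out higher numbers stand for weaker inhibition and lower numbers for stronger inhibition), compound 1 (`C=CCCCCOc1ccccc1-c1cnc(OCCC=C)n1C`) gives 29000 nM, the lower of the two numbers so far. Compound 2 (`C=CCCCCOc1ccc(F)cc1-c1cnc(OCCC=C)n1C`) gives 87000 nM. Going by the values given here, the only measured step, a 3.0-fold higher number from compound 1 to compound 2 (0.48 log units; beyond the scatter), is fluoro in place of hydrogen on an aromatic carbon, so it bears only indirectly on a chain change and serves as a rough guide to size. Compound 3 (`C=CCCCCOc1ccccc1-c1cnc(OCCCCC=C)n1C`) differs from compound 1 as follows: but-3-en-1-yl in place of vinyl on a saturated chain carbon, two bonds along the chain from an oxygen on an aromatic ring. The same difference reads (but-3-en-1-yl)oxy to (hex-5-en-1-yl)oxy. Among the compounds with values here, no measured pair varies this chain, so the direction remains open, and no step beyond the scatter is expected in this assay. The estimated step is a 1.2-fold lower number from compound 1 to compound 3 (0.06 log units; within the scatter), and a wide range is kept around it. The expected value of compound 3 is 25000 nM, with an estimated range from 9000 nM to 70000 nM.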

Compound 3, half-maximal inhibitory concentration: 4000 nM
Estimate against measurement, compound 3: 6.3-fold (0.80 log units) above; measured number below the stated range.
By their numbers in this assay, from the lowest: compound 3; then compound 1; then compound 2.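

The first measured variation of this chain gives a 7.3-fold lower number from compound 1 to compound 3 (0.86 log units; beyond the scatter) in this assay, so this position responds to the change from (but-3-en-1-yl)oxy to (hex-5-en-1-yl)oxy. Both the leaving and the entering group carry one double bond outside aromatic rings and no hydrogen-bond donors or acceptors, so the difference shown lies in chain length, and the number moves in the opposite direction to the one earlier step, a 3.0-fold higher number from compound 1 to compound 2 (0.48 log units; beyond the scatter). No available evidence accounts for this shift.

On these data alone, whether a longer chain, such as oct-7-en-1-yl, would lower the number further remains open. Also open, as far as these compounds go, are whether the terminal double bond matters, as a saturated hexyl chain would show, and how an amine at the chain end would read.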